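The source may hold more compounds than are shown below. What is called first, only, known or untested is meant among the compounds shown, and "the series" means these compounds.

Compound 1 `Cc1c2c(n3c1CC(=O)NCC[C@H](C)Nc1cc-3ccc1C(N)=O)CC(C)(C)CC2=O`: > 0.5 h
Compound 2 `Cc1c2c(n3c1CCCN(C(=O)[C@@H](C)N)[C@H](C)CNc1cc-3ccc1C(N)=O)CC(C)(C)CC2=O`: > 0.5 h

In an in vitro ADME assay on microsomes from liver (Rattus norvegicus) for metabolic stability (a higher number here means that the compound lasts longer, a lower number that the compound disappears faster), compound 1 gives > 0.5 h, which is a limit of the assay and not a number. Compound 2 also gives a limit, > 0.5 h. Compound 1 therefore stands at the limit of > 0.5 h in this assay, at which 2 of the 2 values shown sit. Compound 3 `CC(=O)NCCN1CC[C@H](C)Nc2cc(ccc2C(N)=O)-n2c(c(C)c3c2CC(C)(C)CC3=O)CC1=O` carries 2-acetamidoethyl in place of hydrogen on an amide-type nitrogen in a ring of compound 1 (2-acetamidoethyl in place of hydrogen on an amide-type nitrogen in a ring). For the measured compounds named here, no measured step covers this change, so no step beyond the scatter is expected in this assay, in either direction. The expected change is a number no higher from compound 1 to compound 3 (the limit leaves the size open). Compound 3 is estimated at 0.5 h, within a range of 0.25 h to 1 h.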

Compound 3, half-life: > 0.5 h
Compound 3: no number, only a limit; the forecaster's own chance of this, stated with the estimate: 65%; the middle value sits exactly at the limit.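

Compound 1 and compound 3 both sit at a limit in this assay, so no step can be read between them. The compounds shown leave open how long each actually lasts, and whether 2-acetamidoethyl on the amide-type nitrogen changes that.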